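Changing one pyridine group in a clearance series

A few compounds are considered here, and "the series" means these few. Any claim that something is new, unique, unknown or untested is made for them only; others in the source may bear on it.

Values in an ADME assay (liver) for metabolic stability, with Liver microsome (Rattus norvegicus) as the target, using microsomes and NADPH, with a stated time of 30 min, tested at 1 uM (a lower number here means slower removal, a higher number faster removal of the compound), so far:
Compound 1 `Nc1ccc(S(=O)(=O)N2CCN(c3ncc(C(O)(C(F)(F)F)C(F)(F)F)cc3C#CCO)CC2)cn1`: 65 mL.min-1.g-1
Compound 2 `Nc1ccc(S(=O)(=O)N2CCN(c3ncc(C(O)(C(F)(F)F)C(F)(F)F)cc3-c3cncc(F)c3)CC2)cn1`: 19 mL.min-1.g-1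

Compound 2, at 19 mL.min-1.g-1, holds the lower of the two numbers. Compound 3 `Cc1ccc(-c2cc(C(O)(C(F)(F)F)C(F)(F)F)cnc2N2CCN(S(=O)(=O)c3ccc(N)nc3)CC2)cn1` has 6-methylpyridin-3-yl in place of 5-fluoropyridin-3-yl on an aromatic carbon and has not yet been measured. For the measured compounds named here, only one measured step bears on this change. That step is a 3.4-fold lower number from compound 1 to compound 2 (0.53 log units; beyond the scatter) and is modest but beyond the scatter. Going by the values given here, it introduced 5-fluoropyridin-3-yl itself, so no measured step compares two pyridine groups and it gives only a rough scale. A smaller step is therefore expected in this assay, tentatively towards a higher number and possibly within the scatter. The expected step is a 1.5-fold higher number from compound 2 to compound 3 (0.17 log units; within the scatter) in this reading. For compound 3 the estimated value is 28 mL.min-1.g-1 within an expected range of 14 mL.min-1.g-1 to 55 mL.min-1.g-1 as the likely span.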

Compound 3, intrinsic clearance in microsomes: 182 mL.min-1.g-1
The estimate for compound 3 lay 6.5-fold (0.81 log units) below the measured number; the whole stated range lies below it.
By their numbers in this assay, from the lowest: compound 2; then compound 1; then compound 3.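

In this assay, the aromatic carbon ortho to a large group proved sensitive to the choice of pyridine group: exchanging 5-fluoropyridin-3-yl for 6-methylpyridin-3-yl gave a 9.6-fold higher number from compound 2 to compound 3 (0.98 log units; beyond the scatter), a wider step than a 3.4-fold lower number from compound 1 to compound 2 (0.53 log units; beyond the scatter). A pyridine group at this place therefore does not by itself bring the number down, since replacing 3-hydroxyprop-1-yn-1-yl with 6-methylpyridin-3-yl gave a 2.8-fold higher number from compound 1 to compound 3 (0.45 log units; beyond the scatter), the opposite direction to the step that introduced 5-fluoropyridin-3-yl. Nothing available accounts for the gap between the two pyridine groups.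

The two groups differ both in the substituent and in where it sits on the pyridine, so the compounds shown do not separate these two differences. A 5-methylpyridin-3-yl or 6-fluoropyridin-3-yl group would address that question directly.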